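Thiophene in place of naphthalene on the benzylidene arm

The source may report more compounds than this note shows. Statements on the series, on what has been measured and on what is new or still open speak of the compounds shown alone.

Compound 1, `CC(=O)OC[C@H]1O[C@@H](n2cc(CN3C(=O)/C(=C\c4ccc(C)cc4)c4ccccc43)nn2)[C@H](OC(C)=O)[C@@H](OC(C)=O)[C@@H]1OC(C)=O`: in a functional assay on MCF7 cells (Homo sapiens) for cytotoxicity, read by sulforhodamine B assay, with a stated time of 48 h (on this read-out lower numbers stand for stronger inhibition and higher numbers for weaker inhibition), compound 1 gives > 100000 nM, a limit of the assay.
Compound 2, `CC(=O)OC[C@H]1O[C@@H](n2cc(CN3C(=O)/C(=C\c4ccc5ccccc5c4)c4ccccc43)nn2)[C@H](OC(C)=O)[C@@H](OC(C)=O)[C@@H]1OC(C)=O`: in this assay compound 2 gives 46500 nM.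

Within the data shown here, compound 2 carries the only measured number of the pair; the other value is a limit. Among the measured compounds shown here, its step of an at least 2.1-fold lower number from compound 1 to compound 2 (0.33 log units; beyond the scatter) is the single measured step, and its size is set by the limit of > 100000 nM in this assay, at which 1 of the 2 values shown sits, so only its lower bound is known.

Compound 3, `CC(=O)OC[C@H]1O[C@@H](n2cc(CN3C(=O)/C(=C\c4cccs4)c4ccccc43)nn2)[C@H](OC(C)=O)[C@@H](OC(C)=O)[C@@H]1OC(C)=O`, differs from compound 2 by thiophen-2-yl in place of naphthalen-2-yl on a double-bonded chain carbon bound to a double-bonded ring carbon. For the measured compounds named here, the one measured step bears on it only indirectly: it shows that the naphthalen-2-yl group of compound 2 gives a lower number than the 4-methylphenyl group of compound 1, and thiophen-2-yl is, like 4-methylphenyl, a single ring rather than a fused pair. A return toward the weaker end is therefore expected in this assay, with a real chance that only a limit is reported. Compound 3 is expected at 80000 nM, between 30000 nM and 200000 nM. This estimate corresponds to a step of a 1.7-fold higher number from compound 2 to compound 3 (0.24 log units; within the scatter).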

Compound 3, half-maximal inhibitory concentration: 36100 nM
Estimate against measurement, compound 3: 2.2-fold (0.35 log units) above; low and high end bracket the measured number.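

Replacing naphthalen-2-yl with thiophen-2-yl on the double-bonded chain carbon in this assay gives a 1.3-fold lower number from compound 2 to compound 3 (0.11 log units; within the scatter), so compound 2 and compound 3 cannot be told apart here. Thiophen-2-yl, a single five-membered ring, therefore sits with the two six-membered rings of naphthalen-2-yl and apart from the single six-membered ring of 4-methylphenyl, with an at least 2.7-fold lower number from compound 1 to compound 3 (0.44 log units; beyond the scatter), and compound 3 goes against any reading that a second ring is needed at this position. The size of that step has only a lower bound, and the value of compound 1 is a limit: the limit of > 100000 nM in this assay, at which 1 of the 3 values shown sits.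

The compounds shown leave open whether a plain phenyl, a furan-2-yl or a pyridin-2-yl group at this position would behave like 4-methylphenyl or like thiophen-2-yl. They also leave open whether a phenyl ring bearing an amine or a carboxylic acid would stay in the range of compound 2 and compound 3.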